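Urea in place of amide on a shared core

A few compounds are considered here, and "the series" means these few. Any claim that something is new, unique, unknown or untested is made for them only; others in the source may bear on it.

Within the data shown here, compound 2 `COc1cc(-c2nn(-c3cccc(NC(=O)c4ccc(Cl)c(C(F)(F)F)c4)c3)cc2-c2ccncc2)ccc1Cl` is one of two compounds measured in a functional assay on MCF7 cells (Homo sapiens) for inhibition, read by sulforhodamine B assay, with a stated time of 48 h; on this read-out higher numbers stand for weaker inhibition of growth and lower numbers for stronger inhibition of growth. Here compound 2 gives 2240 nM, the highest of the two numbers. The other, compound 1 `COc1cc(-c2nn(-c3cccc(NC(=O)Nc4ccc(Cl)c(Cl)c4)c3)cc2-c2ccncc2)ccc1Cl`, gives 945 nM. Compound 1 differs from compound 2 at two points at once: the carbonyl carbon carries a (3,4-dichlorophenyl)amino group rather than a 4-chloro-3-(trifluoromethyl)phenyl group, and the step runs a 2.4-fold higher number from compound 1 to compound 2 (0.37 log units; beyond the scatter).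

Compound 3 `COc1cc(-c2nn(-c3cccc(NC(=O)Nc4ccc(Cl)c(C(F)(F)F)c4)c3)cc2-c2ccncc2)ccc1Cl` has not yet been measured. It keeps the shared core and differs from compound 2 by (4-chloro-3-(trifluoromethyl)phenyl)amino in place of 4-chloro-3-(trifluoromethyl)phenyl on a carbonyl carbon. This undoes the amide-to-urea part of the earlier change while keeping the aromatic ring of compound 2. Among the measured compounds shown here, because the only measured step, a 2.4-fold higher number from compound 1 to compound 2 (0.37 log units; beyond the scatter), combines both changes, the share that belongs to the urea alone cannot be separated from the data; the earlier step is the one that bears on this one.

For compound 3 the estimate is 1000 nM in this assay, in a range from 400 nM to 2500 nM. The step this expectation means is a 2.2-fold lower number from compound 2 to compound 3 (0.35 log units; beyond the scatter).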

Compound 3, concentration for 50% growth inhibition: 919 nM
For compound 3 the middle estimate is 1.1-fold (0.04 log units) above the measured one; low and high end bracket the measured number.
By their numbers in this assay, from the lowest: compounds 3 and 1 (each within the scatter of the next); then compound 2.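

Compound 3 separates the two changes that were mixed in the earlier step. With the 4-chloro-3-(trifluoromethyl)phenyl ring held fixed, adding the amino nitrogen on the carbonyl carbon gives a 2.4-fold lower number from compound 2 to compound 3 (0.39 log units; beyond the scatter) in this assay and so turns the amide into a urea with stronger inhibition of growth on this one pair. With the urea held fixed, the other part of the earlier change, trifluoromethyl in place of chloro on an aromatic carbon, gives a 1.0-fold lower number from compound 1 to compound 3 (0.01 log units; within the scatter) and so leaves the two ureas indistinguishable on this read-out, which points to the amide-to-urea change, not the ring, as the part of the earlier step that can be seen here. No measurement shown here says why the added nitrogen goes with this difference.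

Going by these compounds, the urea-over-amide comparison rests on a single pair, so it stays open whether it would hold with other rings on the carbonyl carbon, such as a plain phenyl or a 4-methoxyphenyl. On these data alone, it also stays open whether the hydrogen on the added nitrogen matters, which a urea carrying a methyl group on that nitrogen would address.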